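Halogen exchange on the dimethylsulfonamide member of the series

The source may hold more compounds than are shown below. What is called first, only, known or untested is meant among the compounds shown, and "the series" means these compounds.

Measured compounds:
Compound 1 `NS(=O)(=O)Cc1noc2ccc(Cl)cc12` gives 14 mg/kg in a functional assay on the whole organism (strain STD-dd) with Mus musculus as the target, in the maximal electroshock model, with a stated time of 2 h; on this read-out higher numbers stand for an effect only at larger amounts of compound and lower numbers for an effect already at smaller amounts.
Compound 2 `CNS(=O)(=O)Cc1noc2ccc(Cl)cc12` gives 20 mg/kg in this assay.
Compound 3 `CN(C)S(=O)(=O)Cc1noc2ccc(Cl)cc12` gives 57 mg/kg in this assay.

Compound 3 carries the highest number of the three: a 4.1-fold higher number from compound 1 to compound 3 (0.61 log units; beyond the scatter) and a 2.9-fold higher number from compound 2 to compound 3 (0.45 log units; beyond the scatter), both beyond the scatter, whereas a 1.4-fold higher number from compound 1 to compound 2 (0.15 log units; within the scatter) stays within it. Compound 4 `CN(C)S(=O)(=O)Cc1noc2ccc(Br)cc12` differs from compound 3 by bromo in place of chloro on an aromatic carbon. For the measured compounds named here, none of the measured steps touches this position; all three alter the sulfonamide nitrogen, so no measured step bears on the halogen change. With no guidance from the data, no step beyond the scatter is expected in this assay, and the number for compound 4 is estimated at 57 mg/kg (range 28 mg/kg to 115 mg/kg), an expected step of no change at the digits printed from compound 3 to compound 4 (within the scatter) from compound 3.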

Compound 4, dose for half-maximal effect: 45 mg/kg
The estimate for compound 4 lay 1.3-fold (0.10 log units) above the measured number; the range from low to high includes it.
By their numbers in this assay, from the lowest: compounds 1 and 2 (each within the scatter of the next); then compounds 4 and 3 (each within the scatter of the next).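

In this assay, for the compounds shown here, the exchange of chloro for bromo on an aromatic carbon gives a 1.3-fold lower number from compound 3 to compound 4 (0.10 log units; within the scatter) and is the first measured step at this position rather than on the sulfonamide nitrogen. On this read-out, the two halogens cannot be told apart on the dimethylsulfonamide. No available evidence bears on this result.

Still open, going by these compounds, is whether a methoxy group or a nitrile at this position would give a step beyond the scatter. Also open, on these data alone, is whether the same halogen exchange on the unsubstituted sulfonamide of compound 1 would read the same.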